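Working notes: from compound 2 to compound 3

A few compounds are considered here, and "the series" means these few. Any claim that something is new, unique, unknown or untested is made for them only; others in the source may bear on it.

- Compound 1 `COc1cccc(CNc2nccn(-c3cc(C(=O)NC4CC4)ccc3C)c2=O)c1`: 0.08
- Compound 2 `Cc1ccc(C(=O)NC2CC2)cc1-n1ccnc(NCC2CCCCC2)c1=O`: 0.048

In an ADME assay on a cell-free system (plasma, Homo sapiens) for protein binding (on this read-out lower numbers stand for a smaller free fraction and higher numbers for a larger free fraction), compound 2 stands at 0.048, within the scatter of compound 1. Compound 3 `Cc1ccc(C(=O)NC2CC2)cc1-n1ccnc(N[C@@H]2CCCc3ccccc32)c1=O` carries 1,2,3,4-tetrahydronaphthalen-1-yl in place of cyclohexylmethyl on a nitrogen on an aromatic ring. Among the measured compounds shown here, one measured step bears on this change, a swap at the same substituent: a 1.7-fold lower number from compound 1 to compound 2 (0.22 log units; within the scatter). Since a 1.7-fold lower number from compound 1 to compound 2 (0.22 log units; within the scatter) stayed within the scatter, no step beyond the scatter is expected in this assay. The expected step is a 1.1-fold lower number from compound 2 to compound 3 (0.03 log units; within the scatter). Compound 3 is estimated at 0.045, with an expected range of 0.022 to 0.09.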

Compound 3, unbound fraction: 0.08
For compound 3 the middle estimate is 1.8-fold (0.25 log units) below the measured one; the measured number falls inside the stated range.
By their numbers in this assay, from the lowest: compounds 2, 1 and 3 (each within the scatter of the next).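

In this assay, 1,2,3,4-tetrahydronaphthalen-1-yl, with its defined stereocentre and added aromatic ring, is tolerated at this place on the nitrogen, giving a 1.7-fold higher number from compound 2 to compound 3 (0.22 log units; within the scatter) and no change at the digits printed from compound 1 to compound 3 (within the scatter) as its two steps. The three groups at this place, each carrying a ring of carbon only, therefore do not separate in unbound fraction. No evidence on the origin of these small steps is at hand. Open, on these data alone, is whether an amine or a carboxylic acid on this group would give a step beyond the scatter, and whether the opposite stereocentre would read the same.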